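Notes on the methoxy-to-isobutoxy step in the series

The source may hold more compounds than are shown below. What is called first, only, known or untested is meant among the compounds shown, and "the series" means these compounds.

Three compounds carry measurements in a functional assay on A549 cells (Homo sapiens) for antiproliferative activity, read by sulforhodamine B assay, with a stated time of 72 h; a higher number here means a weaker inhibitor of growth, a lower number a stronger inhibitor of growth. Compound 1 `COc1ccc(Br)c(CSc2ccc3c(C)cc(=O)oc3c2)c1` gives 15300 nM in this assay. For compound 2 `CCc1oc2c(C)c(OCc3ccccc3)ccc2c(=O)c1Br` this assay reports only a limit, > 26700 nM, and not a number. For compound 3 `CCc1cc(=O)c2ccc(OC)c(CBr)c2o1` this assay likewise reports only a limit, > 33600 nM. Compound 3 therefore stands at the edge of what was measured, at the limit of > 33600 nM in this assay, at which 1 of the 3 values shown sits. One other value among the three is also a limit, at the limit of > 26700 nM in this assay, at which 1 of the 3 values shown sits.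

Compound 4 `CCc1cc(=O)c2ccc(OCC(C)C)c(CBr)c2o1` differs from compound 3 by isopropyl in place of hydrogen on a saturated chain carbon bound to an oxygen on an aromatic ring. No step between measured compounds covers a change of this kind, so the numbers shown give no support for any particular size of step in this assay. Compound 3 is known only as a limit, so the step to compound 4 cannot be measured from a fixed starting number; the expectation is for no movement beyond the scatter, with a real chance that compound 4 again ends at a limit. The estimated step is an at least 1.1-fold lower number from compound 3 to compound 4 (0.04 log units; that floor lies within the scatter). For compound 4 the expected value is 30000 nM, with a range from 7000 nM to 120000 nM.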

Compound 4, concentration for 50% growth inhibition: > 29400 nM
Compound 4 was reported as a limit; the forecaster's own chance of this, stated with the estimate: 55%; the middle value does not contradict the limit.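

Compound 3 and compound 4 are both reported only as limits in this assay, so no step can be read between them. The compounds shown leave open whether the methoxy-to-isobutoxy change alters growth inhibition at all, and what number either compound would give.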